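Fluoro on the phenyl ring: expectation for compound 3

A few compounds are considered here, and "the series" means these few. Any claim that something is new, unique, unknown or untested is made for them only; others in the source may bear on it.

Compound 2 `CN(C)CCn1cnnc1-c1cc(Oc2ccc(NC(=O)N/N=C/c3ccccc3)cc2F)ccn1` is the reference point for the next step. Among the compounds with values here, in a functional assay on A549 cells (Homo sapiens) for cytotoxicity, read by MTT assay, with a stated time of 72 h (a higher number here means a weaker inhibitor, a lower number a stronger inhibitor), compound 2 gives 1860 nM, one of only two numbers measured so far; the other belongs to compound 1 `COc1ccc(OC)c(/C=N/NC(=O)Nc2ccc(Oc3ccnc(-c4nncn4CCN(C)C)c3)c(F)c2)c1` and sits within the scatter of it. In this assay compound 1 gives 1950 nM, so no order between the two is claimed. Within the data shown here, the single measured step is a 1.0-fold lower number from compound 1 to compound 2 (0.02 log units; within the scatter), which exchanged the whole aromatic ring on the carbon with a double bond to nitrogen and left the number where it was.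

Compound 3 `CN(C)CCn1cnnc1-c1cc(Oc2ccc(NC(=O)N/N=C/c3ccc(F)cc3)cc2F)ccn1` differs from compound 2 by fluoro in place of hydrogen on an aromatic carbon, para to a large group. Among the measured compounds shown here, the one step that bears on it, from compound 1 to compound 2, touched the same ring with a larger exchange and stayed within the scatter. A fluoro on that ring is therefore expected to move this assay by a 1.1-fold lower number from compound 2 to compound 3 (0.04 log units; within the scatter), no step beyond the scatter in either direction. Compound 3 is estimated at 1700 nM in this assay, within 700 nM to 4200 nM. For the measured compounds named here, no measured step carries a single fluoro, so the range is kept wide.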

Compound 3, half-maximal inhibitory concentration: 1790 nM
Estimate against measurement, compound 3: 1.1-fold (0.02 log units) below, and the stated range covers the measured number.
By their numbers in this assay, from the lowest: compounds 3, 2 and 1 (each within the scatter of the next).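

Fluoro in place of hydrogen on an aromatic carbon, para to a large group, gives a 1.0-fold lower number from compound 2 to compound 3 (0.02 log units; within the scatter) in this assay and is the first single-atom change read on this ring. The wider exchange of 4-fluorophenyl in place of 2,5-dimethoxyphenyl gives a 1.1-fold lower number from compound 1 to compound 3 (0.04 log units; within the scatter) and also stays within the scatter, so the three aryl groups shown on the carbon with a double bond to nitrogen cannot be put in any order in this assay and this position has so far shown no measurable response to either a small or a large exchange. Nothing shown gives a measured reason for this flat reading.

From the compounds shown here alone, whether this holds for other kinds of group remains open: an amine, a carboxylic acid or a longer chain in place of the fluoro could show whether any group at this place on the ring moves the number beyond the scatter. Also open, going by these compounds, is whether a change elsewhere on the shared core, such as in the dimethylamino side chain, would move the number in this assay more than these ring exchanges do.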